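Lengthening a side chain and how much cells tolerate

A few compounds are considered here, and "the series" means these few. Any claim that something is new, unique, unknown or untested is made for them only; others in the source may bear on it.

Compound 1 `CCCCCCc1cc2cn(COCCO)c(=O)nc2o1` and compound 2 `CCCCCCCCCCc1cc2cn(COCCO)c(=O)nc2o1` share one core and differ by butyl in place of hydrogen on a saturated chain carbon, six bonds along the chain from an aromatic carbon. In a functional assay on HEL cells (Homo sapiens), read by microscopy (a lower number here means that less compound is tolerated, a higher number that more compound is tolerated), compound 1 gives >= 400000 nM, which is a limit of the assay and not a number. In this assay compound 2 gives 400000 nM. The step of a number no higher from compound 1 to compound 2 (the limit leaves the size open) cannot be sized, since one of its values sits at the limit of >= 400000 nM in this assay, at which 1 of the 3 values shown sits.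

Compound 3 `CCCCCC#Cc1cc2cn(COCCO)c(=O)nc2o1` has a core that differs from the core of compound 1 by hept-1-yn-1-yl in place of hexyl on an aromatic carbon. In this assay compound 3 gives >= 100000 nM, again a limit rather than a number. The step that the two limits leave unreadable from compound 1 to compound 3 is left open by the two limits the limit of >= 100000 nM in this assay, at which 1 of the 3 values shown sits, and (the limit of >= 400000 nM in this assay, at which 1 of the 3 values shown sits).

Compound 4 `CCCCCCCCCC#Cc1cc2cn(COCCO)c(=O)nc2o1` is not yet measured and differs from compound 3 by butyl in place of hydrogen on a saturated chain carbon, five bonds along the chain from a triple-bonded carbon. The surroundings differ: six bonds along the chain from an aromatic carbon in the first pair, five bonds along the chain from a triple-bonded carbon here, so this is the same kind of change, not the same change. Beside a number no higher from compound 1 to compound 2 (the limit leaves the size open), the expected step is a step that the limit leaves unreadable from compound 3 to compound 4, resting on compound 2 still giving 400000 nM after the same chain extension. Compound 4 is expected to give about 200000 nM, between 50000 nM and 400000 nM, quite possibly again only as a limit.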

Compound 4, minimum cytotoxic concentration: >= 20000 nM
Compound 4: only a limit was reported; the forecaster's own chance of this, stated with the estimate: 50%; the middle value does not contradict the limit.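

In this assay compound 4 gives >= 20000 nM, a limit of the assay and not a number. Compound 3 gives >= 100000 nM, also a limit, so the step between these two compounds cannot be read. The compounds shown leave open whether adding butyl at this place changes how much compound is tolerated in this assay.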